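Swapping the dichlorophenyl amide in a benzothiazole series

The source may report more compounds than this note shows. Statements on the series, on what has been measured and on what is new or still open speak of the compounds shown alone.

Compound 1 `O=C(CSc1cccc(O)c1)Nc1ccc2nc(NC(=O)c3cc(Cl)cc(Cl)c3)sc2c1` — 5440 nM
Compound 2 `Cn1c(CNC(=O)c2cccs2)nnc1SCC(=O)Nc1cccc(Cl)c1` — > 100000 nM
Compound 3 `CCn1c(CNc2ccc(OC)cc2)nnc1SCC(=O)Nc1ccc(Cl)cc1` — 39500 nM

In a functional assay on HCT-116 cells (Homo sapiens) for antiproliferative activity, read by MTT assay, with a stated time of 72 h (on this read-out higher numbers stand for weaker inhibition and lower numbers for stronger inhibition), compound 1 gives 5440 nM, the lower of the two numbers that were obtained. Compound 3 gives 39500 nM in this assay, a gap that lies beyond the usual scatter of repeated measurements. Compound 2 reaches only (the limit of > 100000 nM in this assay, at which 1 of the 3 values shown sits), so for compound 2 the assay reports a limit rather than a number. Compound 4 `Cc1ccc(C(=O)Nc2nc3ccc(NC(=O)CSc4cccc(O)c4)cc3s2)cc1` has not yet been measured. It differs from compound 1 in one place, (4-methylphenyl in place of 3,5-dichlorophenyl on a carbonyl carbon). Among the measured compounds shown here, no measured pair in this set differs in one place, so the size of such a change cannot be read from any measured step. The expectation is that the step of a 1.8-fold higher number from compound 1 to compound 4 (0.26 log units; within the scatter) will be small, in the direction of a weaker effect, and may not exceed the scatter. Compound 4 is therefore estimated at 10000 nM, within a range from 3000 nM to 40000 nM.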

Compound 4, half-maximal inhibitory concentration: 7730 nM
For compound 4 the middle estimate is 1.3-fold (0.11 log units) above the measured one, and the stated range covers the measured number.
By their numbers in this assay, from the lowest: compounds 1 and 4 (each within the scatter of the next); then compound 3. At a limit, above all of these: compound 2.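

Among the compounds shown here, this is the first step in the set that can be read at all, since compounds 2 and 3 differ from compound 1 in more than one place. In this assay, 4-methylphenyl in place of 3,5-dichlorophenyl on a carbonyl carbon gives a 1.4-fold higher number from compound 1 to compound 4 (0.15 log units; within the scatter). For this one pair, then, the two chlorine atoms can give way to a methyl group without a difference this read-out can resolve, so the two compounds count as equal here.

On these data alone, it remains open whether this place would accept a very different group just as well, such as a phenyl ring carrying a carboxylic acid or an amine, or a longer carbon chain in place of the ring. Nothing measured here bears on why 3,5-dichlorophenyl and 4-methylphenyl read alike.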